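The compounds below may be only part of what the source reports. "The series", "measured", "known", "first", "only" and "open" are said of these compounds alone.

Measured compounds:
compound 1 `COc1ccccc1/C=C/C(=O)/C=C/c1ccc(OCc2cn(CCOc3cc(=O)oc4ccccc34)nn2)c(OC)c1`: 11%
compound 2 `COc1ccc(/C=C/C(=O)/C=C/c2ccc(OCc3cn(CCCCCOc4cc(=O)oc5ccccc45)nn3)c(OC)c2)cc1`: "not active" (no number reported)
compound 3 `COc1cc(/C=C/C(=O)/C=C/c2ccco2)ccc1OCc1cn(CCCCOc2cc(=O)oc3ccccc23)nn1`: "not active" (no number reported)

Among the measured compounds shown here, the three measured members were tested in a functional assay on PC-3 cells (Homo sapiens) for inhibition, read by sulforhodamine B assay, with a stated time of 48 h, tested at 50 uM; on this read-out higher numbers stand for more inhibition of growth at the one concentration tested and lower numbers for less inhibition of growth. For the measured compounds named here, compound 1 gives 11%, and this is the only number in the set. Compound 2 is reported only as "not active" (no number reported). Compound 3 is likewise reported only as "not active" (no number reported), so for these two entries no number is known and nothing can be said about how far they lie from compound 1. Compound 1 therefore stands alone as the one quantified result, a low degree of growth inhibition at the single concentration tested.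

The next compound to be measured is compound 4 `COc1cc(/C=C/C(=O)/C=C/c2cccc3ccccc23)ccc1OCc1cn(CCOc2cc(=O)oc3ccccc23)nn1`. Its difference from compound 1 is naphthalen-1-yl in place of 2-methoxyphenyl on a double-bonded chain carbon bound to a double-bonded chain carbon. Going by the values given here, no step between measured compounds exists to calibrate a change of this kind, and the only reference point is the low reading of compound 1. The step in this assay from compound 1 to compound 4 is expected to be small, if anything upward, and likely not beyond the scatter: a number 4 percentage points higher from compound 1 to compound 4 (within the scatter). Compound 4 is accordingly estimated at 15%, with a range from 0% to 35%.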

Compound 4, percent growth inhibition at one concentration: 20%
For compound 4 the middle estimate is 5 percentage points below the measured one; the range from low to high includes it.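

In this assay, among the compounds shown here, naphthalen-1-yl in place of 2-methoxyphenyl on a double-bonded chain carbon bound to a double-bonded chain carbon gives the series its first readable step, a number 9 percentage points higher from compound 1 to compound 4 (within the scatter), and so the first direct look at this position. The entering group has 2 six-membered aromatic rings of carbon only and 0 hydrogen-bond acceptors, against one such ring and 1 hydrogen-bond acceptor in the leaving group, yet the two readings stay within the scatter of each other, so this pair shows no dependence on that acceptor or on the added ring. No measured information is available to explain the result.

The steps involving the two entries reported as not active cannot be read, as those entries carry no number. Open, going by these compounds, is whether an aminophenyl or carboxyphenyl group at this place, or a longer chain in the core of compound 4, would give a reading in this assay that lies beyond the scatter.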